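Aryl in place of alkyl on the amide-type nitrogen

The source may report more compounds than this note shows. Statements on the series, on what has been measured and on what is new or still open speak of the compounds shown alone.

Compound 1 `Cc1ccc(NC(=O)NCCCOc2cccc(CN3CCCCC3)c2)cc1` gives 631 nM in an assay on isolated protein for inhibition of histamine H2 receptor (Cavia porcellus); a higher number here means weaker binding, a lower number tighter binding.
Compound 2 `CCCCNC(=O)NCCCOc1cccc(CN2CCCCC2)c1` gives 81.3 nM in this assay.
Compound 3 `CNC(=O)NCCCOc1cccc(CN2CCCCC2)c1` gives 155 nM in this assay.

Compound 3 stands second highest of the three numbers; its nearest neighbour is compound 2, and a 1.9-fold higher number from compound 2 to compound 3 (0.28 log units; within the scatter) lies within the scatter, while compound 1 sits further off. Compound 4 `COc1ccc(OC)c(NC(=O)NCCCOc2cccc(CN3CCCCC3)c2)c1` differs from compound 3 by 2,5-dimethoxyphenyl in place of methyl on an amide-type nitrogen. The step that bears on this is a 4.1-fold lower number from compound 1 to compound 3 (0.61 log units; beyond the scatter), where methyl took the place of 4-methylphenyl; read the other way, an aryl group on this nitrogen gave the higher number, and a 7.8-fold lower number from compound 1 to compound 2 (0.89 log units; beyond the scatter) points the same way. The step is therefore expected to run toward a higher number, by about a 3.2-fold higher number from compound 3 to compound 4 (0.51 log units; beyond the scatter). Compound 4 is estimated at 500 nM, with a range from 150 nM to 1600 nM.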

Compound 4, dissociation constant: 158 nM
For compound 4 the middle estimate is 3.2-fold (0.50 log units) above the measured one, and the stated range covers the measured number.
By their numbers in this assay, from the lowest: compounds 2, 3 and 4 (each within the scatter of the next); then compound 1.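

In this assay, an aryl group on this amide-type nitrogen does not by itself give the higher number: a 1.0-fold higher number from compound 3 to compound 4 (0.01 log units; within the scatter) and a 1.9-fold higher number from compound 2 to compound 4 (0.29 log units; within the scatter) both stay within the scatter, so 2,5-dimethoxyphenyl sits level with methyl and butyl. The two aryl groups differ instead, with a 4.0-fold lower number from compound 1 to compound 4 (0.60 log units; beyond the scatter) beyond the scatter, which leaves compound 1 alone in standing apart. Nothing available explains that gap between the two aryl groups.

As far as these compounds go, what an unsubstituted phenyl, a single methoxy group or a pyridine ring on this nitrogen would give remains open.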